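Anilide variation on a hexafluoro-carbinol naphthylamine core

The compounds below may be only part of what the source reports. "The series", "measured", "known", "first", "only" and "open" are said of these compounds alone.

Compound 1 `CC(C)C(=O)Nc1c(C(O)(C(F)(F)F)C(F)(F)F)ccc2ccccc12`: 6630 nM
Compound 2 `CCCC(=O)Nc1c(C(O)(C(F)(F)F)C(F)(F)F)ccc2ccccc12`: 131 nM
Compound 3 `O=C(NCCCCCCCl)Nc1c(C(O)(C(F)(F)F)C(F)(F)F)ccc2ccccc12`: 4840 nM

In an assay on LtK cells with ATP-sensitive inward rectifier potassium channel 11 (Homo sapiens) as the target (a higher number here means that more compound is needed for the effect, a lower number that less compound is needed), compound 3 stands second highest of the three numbers, close to compound 1 and far from compound 2. The shared core carries an amide whose carbonyl substituent is the only site of variation. Branching matters: a 51-fold lower number from compound 1 to compound 2 (1.70 log units; beyond the scatter). Extending through a urea also matters: a 37-fold higher number from compound 2 to compound 3 (1.57 log units; beyond the scatter). Compound 4 `COc1cccc(C(=O)Nc2c(C(O)(C(F)(F)F)C(F)(F)F)ccc3ccccc23)c1`, not yet measured, makes the change (3-methoxyphenyl in place of (6-chlorohexyl)amino on a carbonyl carbon). For the measured compounds named here, no measured step covers an aromatic group here, so compound 4 is expected to sit between the extremes of compound 2 and compound 3, with a 4.0-fold lower number from compound 3 to compound 4 (0.61 log units; beyond the scatter) as the estimated step. The estimate for compound 4 is 1200 nM, with range 200 nM to 8000 nM.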

Compound 4, half-maximal effective concentration: 185 nM
Compound 4: the middle estimate sits 6.5-fold (0.81 log units) above what was measured; measured number outside the range, below it.
By their numbers in this assay, from the lowest: compounds 2 and 4 (each within the scatter of the next); then compounds 3 and 1 (each within the scatter of the next).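

In this assay, replacing the (6-chlorohexyl)amino group with 3-methoxyphenyl gives a 26-fold lower number from compound 3 to compound 4 (1.42 log units; beyond the scatter) on the carbonyl carbon, and replacing isopropyl with it gives a 36-fold lower number from compound 1 to compound 4 (1.55 log units; beyond the scatter) at the same place. Replacing propyl gives a 1.4-fold higher number from compound 2 to compound 4 (0.15 log units; within the scatter) and so separates compound 4 from compound 2 by no more than the scatter, which shows that an aromatic ring can match the straight chain at this position, while compound 1 and compound 3 remain the high pair. No measured evidence accounts for these steps. Open, from the compounds shown here alone, is whether the methoxy group of compound 4 contributes, with plain phenyl as the direct comparison, and whether a longer straight chain such as pentyl matches propyl.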